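The compounds below may be only part of what the source reports. "The series", "measured", "known", "first", "only" and "open" are said of these compounds alone.

Compound 1 `O=C1O[C@@H](CO)CN1c1ccc(-n2cc(-c3ccccn3)cn2)c(F)c1`: in an ADME assay on L02 cells (Homo sapiens) for cytotoxicity, read by MTT assay, with a stated time of 48 h (a higher number here means a weaker inhibitor, a lower number a stronger inhibitor), compound 1 gives 59 ug/mL.
Compound 2 `COC(=O)CC1CCN(C[C@H]2CN(c3ccc(-n4cc(-c5ccccn5)cn4)c(F)c3)C(=O)O2)CC1`: in this assay compound 2 gives > 400 ug/mL, a limit of the assay.
Compound 3 `O=C1CCC(=O)N1C[C@H]1CN(c2ccc(-n3cc(-c4ccccn4)cn3)c(F)c2)C(=O)O1`: in this assay compound 3 gives > 400 ug/mL, also a limit.

Compound 3 therefore sits at the limit of > 400 ug/mL in this assay, at which 2 of the 3 values shown sit, a limit rather than a number. Compound 4 `CC(=O)OC[C@H]1CN(c2ccc(-n3cc(-c4ccccn4)cn3)c(F)c2)C(=O)O1` differs from it by acetoxy in place of 2,5-dioxopyrrolidin-1-yl on a saturated chain carbon bound to a saturated ring carbon. Among the compounds with values here, two measured steps bear on this. Leaving the hydroxy of compound 1 for the ring gave an at least 6.7-fold higher number from compound 1 to compound 3 (0.83 log units; beyond the scatter), while a step that the two limits leave unreadable from compound 2 to compound 3. Compound 4 carries acetoxy where compound 1 carries hydroxy, a smaller change than either measured one, so a number somewhat nearer that of compound 1 is expected. Compound 4 is expected to give 180 ug/mL, between 60 ug/mL and 400 ug/mL, which would mean an expected step of an at least 2.2-fold lower number from compound 3 to compound 4 (0.34 log units; beyond the scatter).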

Compound 4, half-maximal inhibitory concentration: > 400 ug/mL
Compound 4 gave a limit, no number (the forecaster's own chance of this, stated with the estimate: 40%); middle value at least 2.2-fold (0.34 log units) away from the limit.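

Acetyl in place of hydrogen on an oxygen on a saturated carbon gave an at least 6.7-fold higher number from compound 1 to compound 4 (0.83 log units; beyond the scatter) in this assay, so a group as small as acetoxy on this saturated chain carbon is enough to leave the measurable range, without the larger groups of compound 2 and compound 3. Compound 4 stands at a limit of the assay, as do compound 2 and compound 3: the limit of > 400 ug/mL in this assay, at which 3 of the 4 values shown sit. The steps among these three cannot be read, so they cannot be ranked.

From the compounds shown here alone, it remains open how far past the limit each lies. Going by these compounds, it also remains open whether an amine or a carboxylic acid at this place would give a number nearer that of compound 1.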